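Moving the Methoxy Group on a Weak Compound

The source may hold more compounds than are shown below. What is called first, only, known or untested is meant among the compounds shown, and "the series" means these compounds.

In a functional assay on MGC-803 cells (Homo sapiens) for cytotoxicity, read by MTT assay, with a stated time of 72 h (on this read-out lower numbers stand for stronger inhibition and higher numbers for weaker inhibition), compound 1 `O=C1C(=Cc2ccc(Cl)cc2)C(=O)N(c2ccc(Cl)cc2)N1c1ccc(Cl)cc1` gives 32600 nM and compound 2 `O=C1C(=Cc2ccc(Br)cc2)C(=O)N(c2ccc(Cl)cc2)N1c1ccc(Cl)cc1` gives 16900 nM, a pair separated by a 1.9-fold lower number from compound 1 to compound 2 (0.29 log units; within the scatter). Compound 3 `COc1ccc(C=C2C(=O)N(c3ccc(Cl)cc3)N(c3ccc(Cl)cc3)C2=O)cc1` reaches only a limit, > 128000 nM. Compound 4 `COc1ccccc1C=C1C(=O)N(c2ccc(Cl)cc2)N(c2ccc(Cl)cc2)C1=O` has 2-methoxyphenyl in place of 4-methoxyphenyl on a double-bonded chain carbon bound to a double-bonded ring carbon. Going by the values given here, the nearest measured steps, an at least 3.9-fold higher number from compound 1 to compound 3 (0.59 log units; beyond the scatter) and an at least 7.5-fold higher number from compound 2 to compound 3 (0.87 log units; beyond the scatter), exchange a halogen for methoxy, and no measured step changes where the methoxy sits. They therefore bear only loosely on this change, and weak activity is expected to persist. The expected outcome, with no clear step beyond the scatter, is an at least 1.4-fold lower number from compound 3 to compound 4 (0.15 log units; that floor lies within the scatter). For compound 4 the estimated value is 90000 nM, within an expected range of 30000 nM to 128000 nM.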

Compound 4, half-maximal inhibitory concentration: 28600 nM
Beside the measured number, compound 4's estimate is 3.1-fold (0.50 log units) above it; the measured number lies below the stated range.
By their numbers in this assay, from the lowest: compounds 2, 4 and 1 (each within the scatter of the next). At a limit, above all of these: compound 3.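

In this assay, going by these compounds alone, the place of the methoxy group matters: 2-methoxyphenyl in place of 4-methoxyphenyl gives an at least 4.4-fold lower number from compound 3 to compound 4 (0.65 log units; beyond the scatter), the first step here that keeps the group and changes only where it sits. A methoxy group as such therefore does not separate compound 3 from the halogen compounds, as the other two steps show: a 1.7-fold higher number from compound 2 to compound 4 (0.23 log units; within the scatter) and a 1.1-fold lower number from compound 1 to compound 4 (0.06 log units; within the scatter). Compound 3 stands only at a limit, so the first step gives a floor and not a size: the limit of > 128000 nM in this assay, at which 1 of the 4 values shown sits.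

As far as these compounds go, whether a hydroxyl group or an amine in place of the methoxy group would behave like compound 4 or like compound 3 remains open. So does whether a halogen would respond to a change of place as the methoxy group does.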